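The source may hold more compounds than are shown below. What is called first, only, known or untested is meant among the compounds shown, and "the series" means these compounds.

Measured so far:
compound 1 `Cc1nnc(SCC(=O)N/N=c2/scc(-c3ccccc3)n2-c2ccccc2)s1` — 197 ug/mL
compound 2 `N#Cc1ccc(-c2cs/c(=N/NC(=O)CSc3ncccn3)n2-c2ccccc2)cc1` — < 3.9 ug/mL (a limit)
compound 3 `O=C(CSc1ncccn1)N/N=c1/scc(-c2ccc([N+](=O)[O-])cc2)n1-c1ccccc1` — 193 ug/mL

In an ADME assay on NIH3T3 cells (Mus musculus) for cytotoxicity, read by MTT assay, with a stated time of 24 h (a lower number here means a stronger inhibitor, a higher number a weaker inhibitor), compound 3 gives 193 ug/mL, the lowest of the two numbers shown. Compound 1 gives 197 ug/mL, which lies within the scatter of compound 3, so the two are not distinguished. For compound 2 the assay reports only a limit, < 3.9 ug/mL (the limit of < 3.9 ug/mL in this assay, at which 1 of the 3 values shown sits).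

Compound 4 `O=C(CSc1ncccn1)N/N=c1/scc(-c2ccccc2)n1-c1ccccc1` differs from compound 3 by hydrogen in place of nitro on an aromatic carbon. For the measured compounds named here, the one measured step at this position is an at least 49-fold higher number from compound 2 to compound 3 (1.69 log units; beyond the scatter); it sets nitro against cyano, not against hydrogen, and gives no guide to the present change. Compound 1 carries phenyl at the same position but differs from compound 3 elsewhere in the structure; its closeness to compound 3 is the only pointer available. On that basis compound 4 is expected to stay near compound 3, a step of a 1.1-fold lower number from compound 3 to compound 4 (0.03 log units; within the scatter), none beyond the scatter. Compound 4 is therefore estimated at 180 ug/mL, range 80 ug/mL to 320 ug/mL.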

Compound 4, half-maximal inhibitory concentration: 107 ug/mL
Estimate against measurement, compound 4: 1.7-fold (0.23 log units) above; the measured number falls inside the stated range.
By their numbers in this assay, from the lowest: compounds 4, 3 and 1 (each within the scatter of the next). At a limit, below all of these: compound 2.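

In this assay, the hydrogen parent shows that the nitro group is not needed for the high number at this position: a 1.8-fold lower number from compound 3 to compound 4 (0.26 log units; within the scatter). The value of compound 2 is a limit, not a number, so hydrogen in place of cyano gives only a bound, an at least 27-fold higher number from compound 2 to compound 4 (1.43 log units; beyond the scatter), and among compounds 2, 3 and 4 the cyano compound alone stands apart: the limit of < 3.9 ug/mL in this assay, at which 1 of the 4 values shown sits. On the sulfur, pyrimidin-2-yl in place of 5-methyl-1,3,4-thiadiazol-2-yl on the unsubstituted phenyl compounds also leaves no readable change: a 1.8-fold lower number from compound 1 to compound 4 (0.27 log units; within the scatter).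

On these data alone, whether the separation belongs to cyano alone, or would also appear with an amine or a carboxylic acid on the same aromatic carbon, stays open. Also open, as far as these compounds go, is whether cyano gives the same separation with 5-methyl-1,3,4-thiadiazol-2-yl on the sulfur.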